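The source may report more compounds than this note shows. Statements on the series, on what has been measured and on what is new or still open speak of the compounds shown alone.

Values so far in a functional assay on SW480 cells (Homo sapiens) for antiproliferative activity, read by MTT assay, with a stated time of 48 h; a lower number here means a stronger inhibitor, a higher number a weaker inhibitor
- compound 1 `C=C(CO)C(CCCCCC)n1cnc2c(Cl)ncnc21` gives 32000 nM
- compound 2 `CCCCCCCCC(CCO)n1cnc2c(OC)ncnc21` gives 24600 nM
- compound 3 `CCCCCCCCC[C@H](CCN=[N+]=[N-])n1cnc2c(Cl)ncnc21` gives 1220 nM

Compound 1 sits level with compound 2 within the scatter, while compound 3 lies lower than compound 1 by a margin well beyond the scatter. Compound 4 `C=C(CO)C(CCCCCCCCC)n1cnc2c(Cl)ncnc21` departs from compound 1 in one place only: propyl in place of hydrogen on a saturated chain carbon, seven bonds along the chain from an aromatic nitrogen and a double-bonded chain carbon. The shared core and the double-bonded chain carbon stay as they are in compound 1.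

For the measured compounds named here, no two measured compounds differ in one place, so the series offers no direct size for this change. The evidence is indirect and mixed. Going by the values given here, compound 3 reaches 1220 nM and carries a chain as long as the one in compound 4, but it differs from compound 4 elsewhere as well. Compound 2 stays at 24600 nM with a chain longer than that of compound 1, and so goes against any simple link between chain length and a lower number. A fall in this assay beyond the scatter is therefore expected, though one that stops short of the gap to compound 3. The estimated change is a 5.3-fold lower number from compound 1 to compound 4 (0.73 log units; beyond the scatter) and carries wide uncertainty. For compound 4 the expected value is 6000 nM, with an estimated range from 1800 nM to 20000 nM.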

Compound 4, half-maximal inhibitory concentration: 27600 nM
Beside the measured number, compound 4's estimate is 4.6-fold (0.66 log units) below it; the whole stated range lies below it.
By their numbers in this assay, from the lowest: compound 3; then compounds 2, 4 and 1 (each within the scatter of the next).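

In this assay, propyl in place of hydrogen on a saturated chain carbon, seven bonds along the chain from an aromatic nitrogen and a double-bonded chain carbon, gives a 1.2-fold lower number from compound 1 to compound 4 (0.06 log units; within the scatter). For the compounds shown here, this pair is the first direct reading of chain length: with the shared core and the double-bonded chain carbon held constant, this extension leaves the number unchanged within the scatter, so at this position the propyl addition alone does not produce a measurable gain in antiproliferative activity. No measurement on hand bears on why the number holds level in this pair.

The compounds shown leave open whether the same flat reading holds for a longer chain at this position, or for a chain that ends in an amine or a carboxylic acid. Going by these compounds alone, they also leave open whether propyl in place of hydrogen would read the same without the double-bonded chain carbon, as this step appears in only the one pair.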